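The source may report more compounds than this note shows. Statements on the series, on what has been measured and on what is new or still open speak of the compounds shown alone.

Compound 1 `CC(C(=O)O)c1nn(Cc2cn3cc(OCC4CC4)c(Cl)cc3n2)c2ccccc2c1=O` gives 31 nM in a functional assay on CHO cells for antagonist activity at sphingosine 1-phosphate receptor 2 (Homo sapiens), read by GTPgammaS binding (a lower number here means a stronger inhibitor, a higher number a weaker inhibitor), the lowest of the two numbers recorded, while compound 2 `O=C(O)Cn1nc(CC(=O)Nc2ccc(OC(F)(F)F)c(Cl)c2)c2ccccc2c1=O` gives 754 nM in this assay, a gap well beyond the scatter. Compound 3 `O=C(O)C1(c2nn(Cc3cn4cc(OCC5CC5)c(Cl)cc4n3)c3ccccc3c2=O)CC1` has not yet been measured in this assay. It differs from compound 1 by 1-carboxycyclopropyl in place of 1-carboxyethyl on an aromatic carbon, the 1-carboxycyclopropyl entering in place of the 1-carboxyethyl on an aromatic carbon. Going by the values given here, no measured pair shows this change, so nothing anchors its size; the step of a 1.0-fold lower number from compound 1 to compound 3 (0.01 log units; within the scatter) is expected to stay within the scatter, with no clear direction. Compound 3 is accordingly estimated at 30 nM, between 10 nM and 90 nM.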

Compound 3, half-maximal inhibitory concentration: 82 nM
For compound 3 the middle estimate is 2.7-fold (0.44 log units) below the measured one, within the range that was stated.
By their numbers in this assay, from the lowest: compound 1; then compound 3; then compound 2.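

In this assay, 1-carboxycyclopropyl in place of 1-carboxyethyl on this aromatic carbon next to the ring nitrogen gives a 2.6-fold higher number from compound 1 to compound 3 (0.42 log units; beyond the scatter). The step is modest, but it shows that this position is sensitive to a change in the group that carries the carboxylic acid, even when the acid itself is kept. No measurement at hand accounts for the step. As far as these compounds go, it remains open how a carboxymethyl group, a primary amide or a tetrazole would fare at this position on the same core.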